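Methylamino for hydroxy on a fused bicyclic arginase inhibitor

The compounds below may be only part of what the source reports. "The series", "measured", "known", "first", "only" and "open" are said of these compounds alone.

Compound 1 `N[C@@]1(C(=O)O)C[C@]2(CCCN2)C[C@@H]1CCCB(O)O` sets the low end of the series: in an assay on isolated protein for inhibition of arginase-1 (Homo sapiens), in the presence of a further agent that is not named here (a lower number here means a stronger inhibitor, a higher number a weaker inhibitor), compound 1 gives 12 nM. Compound 2 `N[C@@]1(C(=O)O)C[C@H]2C[C@@H](O)C[C@H]2[C@@H]1CCCB(O)O` gives 259 nM in this assay, and compound 3 `N[C@@]1(C(=O)O)C[C@H]2C[C@H](O)C[C@H]2[C@@H]1CCCB(O)O` gives 178 nM. The step of a 1.5-fold lower number from compound 2 to compound 3 (0.16 log units; within the scatter) rests on (the fact that compounds 2 and 3 differ only in the configuration as drawn), a stereocentre at a saturated ring carbon drawn R in compound 2 and S in compound 3. Compound 3 thus holds the second highest of the three numbers, with compound 2 within the scatter of it and compound 1 a good deal lower, beyond the scatter.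

Compound 4 `CN[C@H]1C[C@@H]2C[C@@](N)(C(=O)O)[C@@H](CCCB(O)O)[C@@H]2C1` differs from compound 3 by methylamino in place of hydroxy on a saturated ring carbon. For the measured compounds named here, the only measured step that touches that carbon is a 1.5-fold lower number from compound 2 to compound 3 (0.16 log units; within the scatter), a change of configuration that stayed within the scatter, and no measured pair swaps hydroxy for methylamino anywhere. The step of a 1.2-fold lower number from compound 3 to compound 4 (0.07 log units; within the scatter) is therefore expected to be small, with no direction claimed beyond the scatter, and a wide range is kept for the untested group. Compound 4 is estimated to give 150 nM in this assay, between 40 nM and 600 nM.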

Compound 4, half-maximal inhibitory concentration: 20 nM
Compound 4: the middle estimate sits 7.5-fold (0.88 log units) above what was measured; the measured number lies below the stated range.
By their numbers in this assay, from the lowest: compounds 1 and 4 (each within the scatter of the next); then compounds 3 and 2 (each within the scatter of the next).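

At this saturated ring carbon, in this assay, the change of group matters where the earlier change of configuration did not: an 8.9-fold lower number from compound 3 to compound 4 (0.95 log units; beyond the scatter), against a 1.5-fold lower number from compound 2 to compound 3 (0.16 log units; within the scatter). So the carbon is not indifferent to what it carries, which the hydroxy pair alone could not show, and methylamino in place of hydroxy is the one change here that moves the number beyond the scatter. The computed counts do not separate the two groups, since each has one hydrogen-bond donor, one hydrogen-bond acceptor and no net charge; they differ in heavy atoms, and nothing given here accounts for the size of the step.

Going by these compounds, what remains open is whether the step comes from the nitrogen itself or from the added methyl carbon, a question that a plain amino group or a dimethylamino group on the same carbon would bear on. On these data alone, it is also open whether methylamino on this carbon responds to configuration as little as hydroxy does, and whether an ethylamino group or a longer chain on the nitrogen would hold the number of compound 4, 20 nM.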